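The source may report more compounds than this note shows. Statements on the series, on what has been measured and on what is new or still open speak of the compounds shown alone.

Among the measured compounds shown here, compound 2 `COc1ccc2[nH]c3c(c2c1)CCNC31CCN(Cc2ccc(F)c(F)c2)CC1` gives 11000 nM in an assay on FRT cells for positive allosteric modulation of Cystic fibrosis transmembrane conductance regulator variant N1303K (Homo sapiens), in the presence of a further agent that is not named here (a lower number here means that less compound is needed, a higher number that more compound is needed for the effect), the higher of the two numbers measured so far. For the measured compounds named here, its only neighbour, compound 1 `COc1ccc2[nH]c3c(c2c1)CCNC31CCN(Cc2c(F)ccc(Cl)c2F)CC1`, gives 1500 nM in this assay, and the single measured step, a 7.3-fold higher number from compound 1 to compound 2 (0.87 log units; beyond the scatter), exchanged one fluorinated aryl for another on the carbon that joins the ring to the nitrogen.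

Compound 3 `COc1ccc2[nH]c3c(c2c1)CCNC31CCN(C(C)c2ccccc2)CC1` has not yet been measured. It differs from compound 2 in that (1-phenylethyl in place of 3,4-difluorobenzyl on an amine nitrogen in a ring). Going by the values given here, no measured step makes a change of this kind: the fluorines are lost and a methyl appears on the carbon bound to the nitrogen, whereas the step from compound 1 to compound 2 kept that carbon unchanged. That step does show that the group on this nitrogen affects the number, by a modest amount beyond the scatter. With no closer guide, the step of a 1.1-fold lower number from compound 2 to compound 3 (0.04 log units; within the scatter) is expected to be small, with no clear direction, and compound 3 is estimated at 10000 nM, within a range of 3000 nM to 40000 nM.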

Compound 3, half-maximal effective concentration: 20000 nM
The estimate for compound 3 lay 2.0-fold (0.30 log units) below the measured number; measured number inside the range.
By their numbers in this assay, from the lowest: compound 1; then compounds 2 and 3 (each within the scatter of the next).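

In this assay, a 1.8-fold higher number from compound 2 to compound 3 (0.26 log units; within the scatter) shows that 1-phenylethyl and 3,4-difluorobenzyl on this amine nitrogen in a ring cannot be told apart, although the two groups differ both in the fluorines and in a methyl on the carbon bound to the nitrogen. Among the compounds shown here, the a 13-fold higher number from compound 1 to compound 3 (1.12 log units; beyond the scatter) is large, so compound 1, with its 3-chloro-2,6-difluorobenzyl group, now stands apart from both other compounds by steps beyond the scatter, whereas before it had only one such comparison. No measurement given here accounts for this separation or says what sets the group of compound 1 apart from the other two.

Compound 3 carries two changes at once, so the effect of the methyl and the effect of losing the fluorines cannot be separated, and they may either be small or offset each other. Going by these compounds, an unsubstituted benzyl group and a 1-(3-chloro-2,6-difluorophenyl)ethyl group would each isolate one of these changes, and it also remains open whether the chlorine or the particular placing of the fluorines matters more in compound 1.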